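Swapping the biaryl terminus of compound 2

The source may hold more compounds than are shown below. What is called first, only, known or untested is meant among the compounds shown, and "the series" means these compounds.

Among the measured compounds shown here, compound 2 `COC(=O)/C=C/c1cccc(N(Cc2ccc(-c3ccc(F)c(F)c3)cc2)C(=O)C2CCCCC2)c1` gives the lowest of the two numbers so far: in an assay on isolated protein with Bile acid receptor (Homo sapiens) as the target (on this read-out higher numbers stand for an effect only at larger amounts of compound and lower numbers for an effect already at smaller amounts), compound 2 gives 72 nM, whereas compound 1 `COC(=O)/C=C/c1cccc(N(Cc2ccc(/C=C/c3ccccc3F)cc2)C(=O)NC(C)C)c1` in this assay gives 431 nM, a difference well beyond the scatter. Compound 3 `COC(=O)/C=C/c1cccc(N(Cc2ccc(-c3ccc(SC)cc3)cc2)C(=O)C2CCCCC2)c1` keeps everything else from compound 2 and differs in one place: 4-(methylsulfanyl)phenyl in place of 3,4-difluorophenyl on an aromatic carbon. For the measured compounds named here, no measured pair shows this change, so the size of the step is uncertain; a modest shift in either direction, or none beyond the scatter, is expected, a 1.4-fold higher number from compound 2 to compound 3 (0.14 log units; within the scatter). Compound 3 is therefore estimated at 100 nM, within 30 nM to 350 nM.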

Compound 3, half-maximal effective concentration: 69 nM
Beside the measured number, compound 3's estimate is 1.4-fold (0.16 log units) above it; the range from low to high includes it.
By their numbers in this assay, from the lowest: compounds 3 and 2 (each within the scatter of the next); then compound 1.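

On an aromatic carbon para to a large group, replacing 3,4-difluorophenyl with 4-(methylsulfanyl)phenyl gives a 1.0-fold lower number from compound 2 to compound 3 (0.02 log units; within the scatter). This first measured step at the position shows that the two groups are interchangeable on this read-out, although the entering group counts 1 hydrogen-bond acceptor and the leaving group 0. No measured evidence explains why the two groups read alike.

Going by these compounds, it remains open whether a phenyl bearing an amine, a carboxylic acid or a longer chain such as butylsulfanyl would also leave the number unchanged.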